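This account rests on a few compounds, and the source may have more. Where it says the series, first, only, none or still open, it means among the compounds named here.

Compound 1 `CC(CSc1nnc(-c2ccncc2)s1)C(=O)NCc1ccccc1Cl` shows > 50000 nM in an ADME assay on BHK-21 cells (Mesocricetus auratus) for cytotoxicity, with a stated time of 3 days (on this read-out higher numbers stand for lower toxicity in this test and lower numbers for higher toxicity in this test), which is a limit of the assay rather than a number. Compound 1 therefore stands at the limit of > 50000 nM in this assay, at which 1 of the 2 values shown sits. For compound 2 `O=C(CSc1nnc(-c2ccncc2)s1)Nc1ccc(Cl)cc1Cl` the outcome in this assay is "not determined" (no result reported). Compound 3 `CC(CSc1nnc(-c2ccncc2)s1)C(=O)Nc1ccccc1Cl` is not yet measured in this assay; it differs from compound 1 by 2-chlorophenyl in place of 2-chlorobenzyl on an amide-type nitrogen. With only a limit known for compound 1, the step of a number no higher from compound 1 to compound 3 (the limit leaves the size open) is expected to be none beyond the scatter. Compound 3 is accordingly estimated at 50000 nM, in the range 20000 nM to 120000 nM, most likely reported again as a limit.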

Compound 3, half-maximal cytotoxic concentration: > 50000 nM
Compound 3 gave a limit, no number; the forecaster's own chance of this, stated with the estimate: 70%; the middle value sits exactly at the limit.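

Compound 1 and compound 3 both give only a limit of the assay in this assay, so no step between them can be read: the limit of > 50000 nM in this assay, at which 2 of the 3 values shown sit.

The compounds shown leave open whether 2-chlorophenyl in place of 2-chlorobenzyl on an amide-type nitrogen changes the read-out at all.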